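The source may report more compounds than this note shows. Statements on the series, on what has been measured and on what is new or still open speak of the compounds shown alone.

Within the data shown here, compound 3 `COc1ccc(/C=N/NC(=O)CSc2nnc(-c3ccncc3)n2-c2ccccc2)cc1` is one of three compounds measured in a functional assay on HCT-116 cells (Homo sapiens) for inhibition, read by MTT assay, with a stated time of 48 h (a higher number here means a weaker inhibitor, a lower number a stronger inhibitor), where compound 3 gives 19200 nM, the second highest of the three numbers. Its neighbours are compound 1 `Fc1ccccc1CSc1nnc(-c2ccncc2)n1-c1ccccc1`, which in this assay gives 12000 nM, and compound 2 `Brc1ccccc1CSc1nnc(-c2ccncc2)n1-c1ccccc1`, which gives 20200 nM. Among the measured compounds shown here, the only single-point step among them, a 1.7-fold higher number from compound 1 to compound 2 (0.23 log units; within the scatter), lies within the scatter. Compound 4 `O=C(CSc1nnc(-c2ccncc2)n1-c1ccccc1)N/N=C/c1cc(Br)cc(Br)c1O` differs from compound 3 by 3,5-dibromo-2-hydroxyphenyl in place of 4-methoxyphenyl on a carbon with a double bond to nitrogen. For the measured compounds named here, no measured step touches this position, so nothing here argues for a change beyond the scatter. Compound 4 is therefore expected near compound 3, an estimated 15000 nM with a range of 5000 nM to 45000 nM, meaning an expected 1.3-fold lower number from compound 3 to compound 4 (0.11 log units; within the scatter).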

Compound 4, half-maximal inhibitory concentration: 4500 nM
The estimate for compound 4 lay 3.3-fold (0.52 log units) above the measured number; measured number below the stated range.
By their numbers in this assay, from the lowest: compound 4; then compounds 1, 3 and 2 (each within the scatter of the next).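

The aryl group on the carbon with a double bond to nitrogen can move the number: in this assay, 3,5-dibromo-2-hydroxyphenyl in place of 4-methoxyphenyl gives a modest step beyond the scatter (a 4.3-fold lower number from compound 3 to compound 4 (0.63 log units; beyond the scatter)). Among these compounds, the one earlier step, a halogen swap elsewhere, stayed within the scatter. Nothing available explains this change.

The compounds shown do not separate the two bromines from the hydroxyl, since they enter together. From the compounds shown here alone, how an amine or a carboxylic acid on that phenyl would read remains open.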